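One more chain carbon between ring and sulfur group

The source may report more compounds than this note shows. Statements on the series, on what has been measured and on what is new or still open speak of the compounds shown alone.

Compound 3 `N=C(S)CCCCN1N=C(c2ccccc2)CCC1=O` belongs to a small set tested in a functional assay on the whole organism (stomach) with Rattus norvegicus as the target; on this read-out higher numbers stand for an effect only at larger amounts of compound and lower numbers for an effect already at smaller amounts. In this assay compound 3 gives 100 mg/kg, the highest of the two numbers shown. Compound 2 `N=C(S)CCCCCCN1N=C(c2ccccc2)CCC1=O` gives 58.8 mg/kg, and the step of a 1.7-fold higher number from compound 2 to compound 3 (0.23 log units; within the scatter) lies within the scatter, so the two cannot be told apart. Compound 1 `CC(Cn1ncccc1=O)C(=N)S`, built on a different core, gives only a limit in this assay, > 100 mg/kg. That result is the limit of > 100 mg/kg in this assay, at which 1 of the 3 values shown sits.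

Compound 4 `N=C(S)CCCCCN1N=C(c2ccccc2)CCC1=O` is still to be measured. It differs from compound 3 by a group of 4 heavy atoms (2 carbon, 1 nitrogen, 1 sulfur; no ring) in place of a group of 3 heavy atoms (1 carbon, 1 nitrogen, 1 sulfur; no ring), on a saturated chain carbon, four bonds along the chain from an amide-type nitrogen in a ring. This is a change of chain length at the same place as the one behind a 1.7-fold higher number from compound 2 to compound 3 (0.23 log units; within the scatter), which stayed within the scatter, so no step beyond the scatter is expected for compound 4 in this assay. Compound 4 is therefore expected to give about 76 mg/kg, with a range from 40 mg/kg to 150 mg/kg. For compound 4 this means an expected step of a 1.3-fold lower number from compound 3 to compound 4 (0.12 log units; within the scatter).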

Compound 4, dose for half-maximal effect: 100 mg/kg
The estimate for compound 4 lay 1.3-fold (0.12 log units) below the measured number, and the stated range covers the measured number.
By their numbers in this assay, from the lowest: compounds 2, 3 and 4 (each within the scatter of the next).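

The middle chain length adds something the earlier pair could not show. In this assay, adding one chain carbon gives no change at the digits printed from compound 3 to compound 4 (within the scatter), and shortening the chain from its longest form shown gives a 1.7-fold higher number from compound 2 to compound 4 (0.23 log units; within the scatter). With three chain lengths now on the shared core, neither of these steps leaves the scatter, so this read-out cannot tell the three lengths apart, and none of them stands out from the others.

Still open, from the compounds shown here alone, is whether a much longer chain, or an amine or a carboxylic acid in place of the sulfur-bearing end group, would move the number beyond the scatter. Compound 1, on a different core, offers no number to compare with the others, only a limit: the limit of > 100 mg/kg in this assay, at which 1 of the 4 values shown sits.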